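Thioether cinnamamide series: growth inhibition at a single concentration

The source may report more compounds than this note shows. Statements on the series, on what has been measured and on what is new or still open speak of the compounds shown alone.

Measured so far:
compound 1 `COc1ccc(SCc2ccc(/C=C/C(=O)Nc3ccccc3N)cc2)cc1OC` — 80.6%
compound 2 `Nc1ccccc1NC(=O)c1ccc(CSc2ccc(C(F)(F)F)cn2)cc1` — 38.9%

In a functional assay on A549 cells (Homo sapiens) for inhibition, read by CCK-8 assay, with a stated time of 72 h, tested at 8 uM (on this read-out lower numbers stand for less inhibition of growth and higher numbers for more inhibition of growth at the one concentration tested), compound 1 gives 80.6%, the higher of the two numbers; compound 2 gives 38.9%, a gap beyond the scatter. Compound 3 `CCc1ccc(SCc2ccc(/C=C/C(=O)Nc3ccccc3N)cc2)cc1` keeps the core of compound 1 and differs by 4-ethylphenyl in place of 3,4-dimethoxyphenyl on a sulfur. Among the measured compounds shown here, no measured step of this kind exists in the set. The expected step of a number 8.6 percentage points lower from compound 1 to compound 3 (within the scatter) is small, downward but not clearly beyond the scatter, since compound 1 stands at 80.6% and the change is limited to the group on the sulfur. Compound 3 is expected to reach 72%, between 48% and 90%.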

Compound 3, percent growth inhibition at one concentration: 68.6%
Compound 3: the middle estimate sits 3.4 percentage points above what was measured; measured number inside the range.
By their numbers in this assay, from the lowest: compound 2; then compound 3; then compound 1.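

At the group on the sulfur, 4-ethylphenyl in place of 3,4-dimethoxyphenyl gives, in this assay, a number 12 percentage points lower from compound 1 to compound 3 (beyond the scatter), a modest step. Growth inhibition at this position therefore does not depend entirely on the 2 oxygen atoms of the group that leaves, since a carbon-only aryl group retains much of it. Nothing available explains the size of this step.

Going by these compounds, because the oxygen atoms and the ethyl group change together, their separate contributions stay open. On these data alone, how a carboxylic acid or an amine on this aromatic ring would read also remains open.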